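Trimming the amine substituent down to hydrogen

A few compounds are considered here, and "the series" means these few. Any claim that something is new, unique, unknown or untested is made for them only; others in the source may bear on it.

Measured so far:
compound 1 `COc1ccc(CN2CCC[C@H]2COC(c2ccccc2)c2ccc(Cl)cc2)cc1` — 2000 nM
compound 2 `COc1ccc(CCCN2CCC[C@H]2COC(c2ccccc2)c2ccc(Cl)cc2)cc1` — 1000 nM

For the measured compounds named here, in a functional assay on Jurkat cells (Homo sapiens) for inhibition, read by calcium flux (a lower number here means a stronger inhibitor, a higher number a weaker inhibitor), compound 2 gives 1000 nM, the lowest of the two numbers so far, and its only neighbour is compound 1 at 2000 nM. Going by the values given here, the one measured step, a 2.0-fold lower number from compound 1 to compound 2 (0.30 log units; within the scatter), lengthened the chain on the ring nitrogen while keeping the aromatic group, and it stayed within the scatter. Compound 3 `CN1CCC[C@H]1COC(c1ccccc1)c1ccc(Cl)cc1` goes much further: hydrogen in place of 2-(4-methoxyphenyl)ethyl on a saturated chain carbon bound to an amine nitrogen in a ring. The whole chain with its aromatic ring is gone, leaving only the small substituent on the nitrogen. Among the compounds with values here, no measured pair shows what removing that group does; the measured step only suggests that the length of the chain matters little. Because compound 2 gives 1000 nM with the whole 2-(4-methoxyphenyl)ethyl group in place and the change to hydrogen is larger than anything measured, a weaker inhibitor is expected, with the step of a 5.0-fold higher number from compound 2 to compound 3 (0.70 log units; beyond the scatter) in this assay estimated as a clear rise. The value for compound 3 is estimated at 5000 nM, within a range from 1500 nM to 20000 nM.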

Compound 3, half-maximal inhibitory concentration: 30000 nM
Beside the measured number, compound 3's estimate is 6.0-fold (0.78 log units) below it; measured number outside the range, above it.
By their numbers in this assay, from the lowest: compounds 2 and 1 (each within the scatter of the next); then compound 3.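

In this assay, the group at this position turns out to matter far more than the earlier pair suggested: removing 2-(4-methoxyphenyl)ethyl gives a 30-fold higher number from compound 2 to compound 3 (1.48 log units; beyond the scatter), and removing 4-methoxyphenyl gives a 15-fold higher number from compound 1 to compound 3 (1.18 log units; beyond the scatter). Changing the chain length while keeping the aromatic ring stayed within the scatter, whereas losing the chain and its ring together goes well beyond it, so inhibition in these compounds depends on having such a group in place. Nothing available here explains this rise.

The compounds shown cannot separate the contribution of the aromatic ring from that of the chain carrying it, a question that a plain butyl chain with no ring could help to answer. They also leave open whether a longer chain or a different ring, such as pyridine, would lower the number.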